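This account rests on a few compounds, and the source may have more. Where it says the series, first, only, none or still open, it means among the compounds named here.

Measured so far:
Compound 1 `CC1CCC(/C=N/c2ccccc2F)=C2NC=C(C(=O)O)C(=O)N21`: 14.5 umol/kg
Compound 2 `CC1CCC(/C=N/c2ccc(F)cc2)=C2NC=C(C(=O)O)C(=O)N21`: 10.6 umol/kg

For the measured compounds named here, in a functional assay on the whole organism with Rattus norvegicus as the target (a lower number here means that less compound is needed, a higher number that more compound is needed for the effect), compound 2 gives the lowest of the two numbers, yet the only step recorded, a 1.4-fold lower number from compound 1 to compound 2 (0.14 log units; within the scatter), is within the scatter, so the two are not separated. Compound 3 `CCOc1ccc(/N=C/C2=C3NC=C(C(=O)O)C(=O)N3C(C)CC2)cc1` differs from compound 2 in one place: ethoxy in place of fluoro on an aromatic carbon. Going by the values given here, no measured step bears on an ethoxy at this position; the one known step moved a fluoro around the ring and changed nothing beyond the scatter. Compound 3 is therefore expected to stay near compound 2, with a 1.1-fold lower number from compound 2 to compound 3 (0.03 log units; within the scatter). The estimate for compound 3 is 10 umol/kg, within 4 umol/kg to 25 umol/kg.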

Compound 3, dose for 50% inhibition: 8.96 umol/kg
Compound 3: middle estimate off by 1.1-fold (0.05 log units), on the high side; the measured number falls inside the stated range.
By their numbers in this assay, from the lowest: compounds 3, 2 and 1 (each within the scatter of the next).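

In this assay the change gives a 1.2-fold lower number from compound 2 to compound 3 (0.07 log units; within the scatter) and so does not separate the two compounds. The earlier compounds shown here only moved a fluoro around the ring, whereas this step shows that the position, para to a large group, takes ethoxy, with its 3 heavy atoms and 1 hydrogen-bond acceptor, in place of fluoro without a change beyond the scatter. No evidence on the reason for this is available. From the compounds shown here alone, how an amine, a carboxylic acid or a longer chain would read at this position remains open, and so does how far the position's tolerance extends.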